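This account rests on a few compounds, and the source may have more. Where it says the series, first, only, none or still open, it means among the compounds named here.

Measured so far in a functional assay on HepG2 cells (Homo sapiens) for antiproliferative activity, read by MTT assay, with a stated time of 24 h; a higher number here means a weaker inhibitor, a lower number a stronger inhibitor:
compound 1 `Sc1nnc(-c2ccc3c(c2)OCCO3)n1-c1ccccc1`: 60000 nM
compound 2 `O=[N+]([O-])c1cccc(CSc2nnc(-c3ccc4c(c3)OCCO4)n2-c2ccccc2)c1`: 49300 nM
compound 3 `Cc1ccccc1CSc1nnc(-c2ccc3c(c2)OCCO3)n1-c1ccccc1`: 20500 nM

Compound 3 has the lowest number of the three, which makes it the strongest inhibitor of this small set. The data show a 2.9-fold lower number from compound 1 to compound 3 (0.47 log units; beyond the scatter) and a 2.4-fold lower number from compound 2 to compound 3 (0.38 log units; beyond the scatter). By contrast, the data show a 1.2-fold lower number from compound 1 to compound 2 (0.09 log units; within the scatter).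

Compound 4 `Fc1ccc(CSc2nnc(-c3ccc4c(c3)OCCO4)n2-c2ccccc2)cc1` keeps the shared core but has 4-fluorophenyl in place of 2-methylphenyl on a saturated chain carbon bound to a sulfur. For the measured compounds named here, no measured compound carries fluorine, so the evidence is indirect. Going by the values given here, the closest precedent is a 2.4-fold lower number from compound 2 to compound 3 (0.38 log units; beyond the scatter), the only measured swap of the group at this same place. It suggests that such a swap moves the number only a little. Compound 3 already sits at the low end with 20500 nM, so a small move toward a higher number is expected in this assay, possibly no larger than the scatter. The expected change is a 1.5-fold higher number from compound 3 to compound 4 (0.17 log units; within the scatter). For compound 4 the estimate is 30000 nM, with an expected range of 13000 nM to 60000 nM.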

Compound 4, half-maximal inhibitory concentration: 1020 nM
Compound 4: middle estimate off by 29-fold (1.47 log units), on the high side; the whole stated range lies above it.
By their numbers in this assay, from the lowest: compound 4; then compound 3; then compounds 2 and 1 (each within the scatter of the next).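

In this assay, for the compounds shown here, the group on a saturated chain carbon bound to a sulfur can matter far more than the earlier compounds suggested: 4-fluorophenyl in place of 2-methylphenyl gives a 20-fold lower number from compound 3 to compound 4 (1.30 log units; beyond the scatter), even though the two groups have the same heavy-atom count and one aromatic ring each. The gap widens against the 3-nitrophenyl group, with a 48-fold lower number from compound 2 to compound 4 (1.68 log units; beyond the scatter), and against hydrogen on the sulfur, with a 59-fold lower number from compound 1 to compound 4 (1.77 log units; beyond the scatter), so the identity of the benzyl group matters, not merely the presence of one. Nothing in the available data explains the size of these steps.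

The compounds shown do not separate the gain of fluorine from the loss of methyl, as this swap changes both at once. Going by these compounds, it also remains open how plain benzyl, 4-chlorobenzyl or a longer chain carrying the 4-fluorophenyl on the sulfur would compare.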